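Replacing 1H-benzimidazol-2-yl with cyclopropyl: expected effect on compound 4

A few compounds are considered here, and "the series" means these few. Any claim that something is new, unique, unknown or untested is made for them only; others in the source may bear on it.

Compound 1, `Cc1cc(Nc2cc(-c3ccccc3)[nH]n2)n2nc(SCc3ccc([N+](=O)[O-])cc3)nc2n1`: 4250 nM in a functional assay on MGC-803 cells (Homo sapiens) for inhibition, read by MTT assay, with a stated time of 72 h; a higher number here means a weaker inhibitor, a lower number a stronger inhibitor
Compound 2, `Cc1cc(Nc2cc(-c3ccccc3)[nH]n2)n2ncnc2n1`: 21700 nM
Compound 3, `Cc1cc(Nc2cc(-c3ccccc3)[nH]n2)n2nc(SCc3nc4ccccc4[nH]3)nc2n1`: 1790 nM

Compound 3 gives the lowest number of the three and is the strongest inhibitor measured here. Compound 4, `Cc1cc(Nc2cc(-c3ccccc3)[nH]n2)n2nc(SCC3CC3)nc2n1`, differs from compound 3 by cyclopropyl in place of 1H-benzimidazol-2-yl on a saturated chain carbon bound to a sulfur. For the measured compounds named here, two measured steps bear on this position. a 12-fold lower number from compound 2 to compound 3 (1.08 log units; beyond the scatter) shows that the whole group attached through sulfur matters a great deal. a 2.4-fold lower number from compound 1 to compound 3 (0.38 log units; beyond the scatter) shows that exchanging the ring at the end of that chain shifts the number less. The group entering carries no aromatic ring and no hydrogen-bond donor or acceptor, so a weaker inhibitor than compound 3 is expected, though not as weak as compound 2. The expected step is a 3.4-fold higher number from compound 3 to compound 4 (0.53 log units; beyond the scatter). Compound 4 is estimated at 6000 nM, in the range 2500 nM to 15000 nM.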

Compound 4, half-maximal inhibitory concentration: 16100 nM
Beside the measured number, compound 4's estimate is 2.7-fold (0.43 log units) below it; the measured number lies above the stated range.
By their numbers in this assay, from the lowest: compound 3; then compound 1; then compounds 4 and 2 (each within the scatter of the next).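

The step of a 1.3-fold lower number from compound 2 to compound 4 (0.13 log units; within the scatter) in this assay shows that (cyclopropylmethyl)sulfanyl on this aromatic carbon does no measurably better than hydrogen. The gain at this position therefore needs more than the sulfur-linked chain: a 9.0-fold higher number from compound 3 to compound 4 (0.95 log units; beyond the scatter) when cyclopropyl replaces 1H-benzimidazol-2-yl and a 3.8-fold higher number from compound 1 to compound 4 (0.58 log units; beyond the scatter) when it replaces 4-nitrophenyl both point to the aromatic end group. No measured evidence here explains this difference. Still open, going by these compounds, is whether an unsubstituted phenyl or an amine at the chain end would keep the gain, and whether a longer chain would alter it.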